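The source may report more compounds than this note shows. Statements on the series, on what has been measured and on what is new or still open speak of the compounds shown alone.

A short series built on one shared core offers a single measured step and one open question. Compound 1, `O=C(N/N=C/c1ccc(Cl)cc1)c1cccnc1`, is tested in an ADME assay on MT4 cells (Homo sapiens) for cytotoxicity, read by MTT assay, with a stated time of 4 days (a lower number here means that less compound is tolerated, a higher number that more compound is tolerated), where compound 1 gives 76 ug/mL. Compound 2, `O=C(N/N=C/c1ccc(F)cc1)c1cccnc1`, carries fluoro where compound 1 carries chloro. For compound 2 the assay reports only a limit, > 125 ug/mL, and not a number. That limit is the one noted as the limit of > 125 ug/mL in this assay, at which 1 of the 2 values shown sits. The measured step, an at least 1.6-fold higher number from compound 1 to compound 2 (0.21 log units; that floor lies within the scatter), is known only as a floor, and that floor lies within the ordinary scatter, so compound 2 stands at the edge of the assay with no fixed number to its name. Compound 3, `O=C(N/N=C/c1ccc([N+](=O)[O-])cc1)c1cccnc1`, is not yet measured. It differs from compound 2 by nitro in place of fluoro on an aromatic carbon. Going by the values given here, no measured step brings in a nitro group, so the chloro-to-fluoro step is the only guide, and it showed no change beyond the scatter. The expectation for this assay is therefore a step of no clear direction. For compound 3 the estimate is 100 ug/mL, ranging from 40 ug/mL to 250 ug/mL, which as a step means an expected at least 1.2-fold lower number from compound 2 to compound 3 (0.09 log units; that floor lies within the scatter).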

Compound 3, half-maximal cytotoxic concentration: 0.1 ug/mL
Beside the measured number, compound 3's estimate is 1000-fold (3.00 log units) above it, outside the stated range (below it).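

The earlier step, chloro to fluoro, stayed within the scatter and could suggest that this place on the ring matters little, but nitro changes that picture. In this assay, putting nitro on an aromatic carbon para to a large group brings an at least 1200-fold lower number from compound 2 to compound 3 (3.09 log units; beyond the scatter), and the comparison with the chloro compound brings a 760-fold lower number from compound 1 to compound 3 (2.88 log units; beyond the scatter), so both steps go the same way and both lie far beyond the scatter. The first of these steps is only a floor and its true size could be larger, because compound 2 has no exact number, only a limit: the limit of > 125 ug/mL in this assay, at which 1 of the 3 values shown sits.

Going by these compounds alone, what nitro does here that fluoro and chloro do not remains unexplained, as these three compounds show only that the group at this one place can make a very large difference to how much compound the cells tolerate. An amine or a nitrile at the same place would help show whether this large drop belongs to nitro alone or extends to other groups.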